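Swapping Methyl for Chloro on a Hydrazone Benzamide

The source may hold more compounds than are shown below. What is called first, only, known or untested is meant among the compounds shown, and "the series" means these compounds.

Measured compounds:
Compound 1, `O=C(N/N=C/c1cc(I)cc(I)c1O)c1ccc(Br)cc1`: 22300 nM
Compound 2, `Cc1ccc(C(=O)N/N=C/c2cc(I)c(O)c(I)c2)cc1`: > 100000 nM

In a functional assay on HepG2 cells (Homo sapiens) for cytotoxicity, with a stated time of 24 h (a higher number here means a weaker inhibitor, a lower number a stronger inhibitor), compound 1 gives 22300 nM. In this assay compound 2 gives only a limit of > 100000 nM and no number, as noted (the limit of > 100000 nM in this assay, at which 1 of the 2 values shown sits); compound 2 therefore stands at the weak end of what is shown, with no exact value. Compound 3, `O=C(N/N=C/c1cc(I)c(O)c(I)c1)c1ccc(Cl)cc1`, has not yet been measured in this assay. It differs from compound 2 by chloro in place of methyl on an aromatic carbon. Among the compounds with values here, because compound 2 sits at the limit of > 100000 nM in this assay, at which 1 of the 2 values shown sits, no measured step is available, and the size of the change from a methyl to a chloro group here is unknown. Compound 3 is expected to be a modestly stronger inhibitor than compound 2, which would mean a step of an at least 2.0-fold lower number from compound 2 to compound 3 (0.30 log units; that floor lies within the scatter). For compound 3 the estimate is 50000 nM, with a range from 15000 nM to 150000 nM.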

Compound 3, half-maximal inhibitory concentration: > 100000 nM
Compound 3: no number, only a limit (the forecaster's own chance of this, stated with the estimate: 45%); at least 2.0-fold (0.30 log units) between middle value and limit.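

In this assay no step can be read from compound 2 to compound 3, because each of the two gives only a limit and no number: the limit of > 100000 nM in this assay, at which 2 of the 3 values shown sit.

The compounds shown leave open whether chloro in place of methyl changes the read-out at all, and by how much.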